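Swapping 3-nitrophenyl for 4-nitrophenyl on compound 1

The source may hold more compounds than are shown below. What is called first, only, known or untested is meant among the compounds shown, and "the series" means these compounds.

- compound 1 `CCCOc1c(Br)cc(/C=C2\CCC/C(=C\c3cccc([N+](=O)[O-])c3)C2=O)cc1OC` gives 0.85 ug/mL here
- compound 2 `CCCCOc1c(Br)cc(/C=C2\CCC/C(=C\c3cccc([N+](=O)[O-])c3)C2=O)cc1OC` gives 5.97 ug/mL here

In a functional assay on MCF7 cells (Homo sapiens) for cytotoxicity, read by MTT assay (a higher number here means a weaker inhibitor, a lower number a stronger inhibitor), compound 1 stands lowest of the two measured compounds, at 0.85 ug/mL here. Compound 3 `CCCOc1c(Br)cc(/C=C2\CCC/C(=C\c3ccc([N+](=O)[O-])cc3)C2=O)cc1OC` has 4-nitrophenyl in place of 3-nitrophenyl on a double-bonded chain carbon bound to a double-bonded ring carbon and is otherwise the same. Going by the values given here, the only measured step, a 7.0-fold higher number from compound 1 to compound 2 (0.85 log units; beyond the scatter), lies on the saturated chain, not on the nitrophenyl. It bears only loosely, showing that one small change can move the number beyond the scatter. Among the compounds with values here, no measured step tests this swap, so only a modest rise is expected, and its direction is uncertain. The expected change is a 1.8-fold higher number from compound 1 to compound 3 (0.25 log units; within the scatter) in this assay here. The estimate for compound 3 is 1.5 ug/mL, with an expected range of 0.4 ug/mL to 6 ug/mL here.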

Compound 3, half-maximal inhibitory concentration: 7.98 ug/mL
Estimate against measurement, compound 3: 5.3-fold (0.73 log units) below; measured number outside the range, above it.
By their numbers in this assay, from the lowest: compound 1; then compounds 2 and 3 (each within the scatter of the next).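

In this assay, replacing 3-nitrophenyl with 4-nitrophenyl gives a 9.4-fold higher number from compound 1 to compound 3 (0.97 log units; beyond the scatter) even though the two compounds have the same atoms. The earlier step showed sensitivity on the saturated chain, whereas this one shows that the number also depends on how the nitrophenyl is joined at this place. Nothing available explains this difference. Going by these compounds, whether a phenyl ring carrying an amine instead of the nitro group would stay near compound 1 at 0.85 ug/mL remains open. So does the effect of an unsubstituted phenyl here.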